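A few compounds are considered here, and "the series" means these few. Any claim that something is new, unique, unknown or untested is made for them only; others in the source may bear on it.

In a functional assay on K562 cells (Homo sapiens) for antiproliferative activity, read by MTT assay, with a stated time of 5 days (on this read-out higher numbers stand for weaker inhibition and lower numbers for stronger inhibition), compound 2 `COc1ccc(/C=C(/C(=O)c2cc(OC)c(OC)c(OC)c2)c2ccccc2O)cc1` gives 370000 nM, the lowest of the two plain numbers shown. Among the measured compounds shown here, compound 3 `COc1ccc(C=C(C(=O)c2cc(OC)c(OC)c(OC)c2)c2ccccc2)cc1F` gives 790000 nM in this assay, a gap to compound 2 that lies beyond the usual scatter, though the two structures differ in two places, so no single step joins them. Compound 1 `COc1ccc(C=C(C(=O)c2cc(OC)c(OC)c(OC)c2)c2ccccc2)cc1[N+](=O)[O-]` produced no number at all but only (the limit of > 10000000 nM in this assay, at which 1 of the 3 values shown sits), recorded as > 10000000 nM. For the measured compounds named here, the one measured single step runs from that limit: an at least 12-fold lower number from compound 1 to compound 3 (1.10 log units; beyond the scatter), a change of fluoro in place of nitro on an aromatic carbon.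

Compound 4 `COc1ccc(/C=C(/C(=O)c2cc(OC)c(OC)c(OC)c2)c2ccccc2O)cc1F` differs from compound 2 by fluoro in place of hydrogen on an aromatic carbon. Going by the values given here, no measured step makes exactly this change, so the expectation rests on the neighbours: compound 3, which carries the same fluoro, gives a number not far from compound 2, and the large step from compound 1 concerns the loss of nitro rather than the arrival of fluoro. A shift within the scatter, in either direction, is therefore expected. For compound 4 the estimate is 300000 nM, with a likely range from 100000 nM to 1200000 nM. That estimate amounts to an expected 1.2-fold lower number from compound 2 to compound 4 (0.09 log units; within the scatter).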

Compound 4, half-maximal inhibitory concentration: 60000 nM
For compound 4 the middle estimate is 5.0-fold (0.70 log units) above the measured one; the whole stated range lies above it.
By their numbers in this assay, from the lowest: compound 4; then compound 2; then compound 3. At a limit, above all of these: compound 1.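

Among the compounds shown here, until now, the only step involving fluoro at this place swapped it for nitro, so it could not show what fluoro does compared with plain hydrogen. Here, in this assay, fluoro replaces a hydrogen on the aromatic carbon ortho to a methoxy group, turning 4-methoxyphenyl into 3-fluoro-4-methoxyphenyl, and a 6.2-fold lower number from compound 2 to compound 4 (0.79 log units; beyond the scatter) follows, so this one added atom moves the result towards stronger inhibition by more than repeat measurements would normally vary. The data shown offer no measurement that explains why this small change has this effect.

This step was read only on compounds that carry the hydroxy group on the second phenyl ring, so it remains open whether fluoro would give a similar shift on a partner compound without that hydroxy group, where compound 3 has no hydrogen-bearing counterpart among those shown. Going by these compounds, it is also open whether the gain is particular to fluoro or would be shared by other groups at this place, such as chloro, a methyl group or an amine.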